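A few compounds are considered here, and "the series" means these few. Any claim that something is new, unique, unknown or untested is made for them only; others in the source may bear on it.

The measured compounds so far:
Compound 1, `COC1=C(OC)[C@H](O)[C@H](C/C=C(\C)CC/C=C(\C)C[C@H](O)/C=C(\C)CO)[C@@H](C)C1=O`, gives 12000 nM in a functional assay on A549 cells (Homo sapiens) for inhibition, read by sulforhodamine B assay, with a stated time of 48 h; a higher number here means a weaker inhibitor of growth, a lower number a stronger inhibitor of growth.
Compound 2, `COC1=C(OC)[C@H](O)[C@H](C/C=C(\C)CC/C=C(\C)CCC=C(C)C)[C@@H](C)C1=O`, gives 5700 nM in this assay.
Compound 3, `COC1=CC(=O)C(C/C=C(\C)CC/C=C(\C)CCC=C(C)C)=C(C)C1=O`, reaches only the limit of > 30000 nM in this assay, so no number is known for it.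

Among the two compounds with a number, compound 2 stands lowest; compound 1 sits a 2.1-fold lower number from compound 1 to compound 2 (0.32 log units; beyond the scatter) away, and that step is the only measured one that bears on what follows. It shows that taking the two oxygen-bearing carbons off the long chain of compound 1 to give compound 2 went with a modestly lower number.

Compound 4, `COC1=C(OC)[C@H](O)[C@H](C/C=C(\C)CC/C=C(\C)CCCC(C)CO)[C@@H](C)C1=O`, is not yet measured. It differs from compound 2 in one place: 2-(hydroxymethyl)propyl in place of 2-methylprop-1-en-1-yl on a saturated chain carbon, two bonds along the chain from a double-bonded chain carbon. Among the measured compounds shown here, the change puts a hydroxyl-bearing, saturated end back onto the chain, which is the reverse direction of the only relevant measured step. On that basis a modest rise in the number is expected, of about the same size, though the scatter of the assay could swallow it. The estimate for compound 4 in this assay is 10000 nM, within 4000 nM to 25000 nM, corresponding to an expected step of a 1.8-fold higher number from compound 2 to compound 4 (0.24 log units; within the scatter).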

Compound 4, concentration for 50% growth inhibition: 7100 nM
Beside the measured number, compound 4's estimate is 1.4-fold (0.15 log units) above it, within the range that was stated.
By their numbers in this assay, from the lowest: compounds 2, 4 and 1 (each within the scatter of the next, the first and the last beyond it). At a limit, above all of these: compound 3.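

In this assay, putting 2-(hydroxymethyl)propyl in place of 2-methylprop-1-en-1-yl, on a saturated chain carbon, two bonds along the chain from a double-bonded chain carbon, gives a 1.2-fold higher number from compound 2 to compound 4 (0.10 log units; within the scatter) and so the two numbers cannot be told apart. This shows that, in this pair, the chain end can lose its double bond and gain a hydroxymethyl group with no measurable difference in growth inhibition. The other new comparison, a 1.7-fold lower number from compound 1 to compound 4 (0.23 log units; within the scatter), also stays inside the scatter, so compound 4 cannot be separated from either neighbour, even though a 2.1-fold lower number from compound 1 to compound 2 (0.32 log units; beyond the scatter) is a step beyond the scatter, and the hydroxymethyl end alone therefore cannot be tied to that modest gap.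

On these data alone, whether this chain end would give the same result with a carboxylic acid, an amine, or a longer chain remains open, as does whether a hydroxymethyl group placed elsewhere on the chain would behave as it does here. The compounds shown offer no measurement that explains why these numbers lie so close together.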